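This account rests on a few compounds, and the source may have more. Where it says the series, first, only, none or still open, it means among the compounds named here.

Measured in a toxicity assay on CCRF-CEM cells (Homo sapiens) for cytotoxicity; on this read-out higher numbers stand for lower toxicity in this test and lower numbers for higher toxicity in this test:
- compound 1 `N#Cc1cccc2c1nc(-c1c(F)cccc1F)n2Cc1c(F)cccc1F`: 26.7 uM
- compound 2 `N=C(NO)c1cccc2c1nc(-c1c(F)cccc1F)n2Cc1c(F)cccc1F`: 23.1 uM
- compound 3 `NC(=O)c1cccc2c1nc(-c1c(F)cccc1F)n2Cc1c(F)cccc1F`: > 100 uM (a limit, not a number)

Compound 3 gives no number in this assay, only the limit > 100 uM. That reading is the limit of > 100 uM in this assay, at which 1 of the 3 values shown sits.

The next step leads to compound 4 `CN(C)C(=O)c1cccc2c1nc(-c1c(F)cccc1F)n2Cc1c(F)cccc1F`: dimethylamino in place of amino on a carbonyl carbon. In words, dimethylamino stands in place of amino on a carbonyl carbon, which turns carbamoyl to dimethylcarbamoyl.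

Among the measured compounds shown here, no measured step changes the carbamoyl group itself, so the evidence is indirect. For the measured compounds named here, two steps bear on it: an at least 3.7-fold higher number from compound 1 to compound 3 (0.57 log units; beyond the scatter) and an at least 4.3-fold higher number from compound 2 to compound 3 (0.63 log units; beyond the scatter). Both lie beyond the scatter and show that carbamoyl, in place of the groups in compound 1 and compound 2, gives the reading at the limit. The remaining step, a 1.2-fold lower number from compound 1 to compound 2 (0.06 log units; within the scatter), lies within the scatter, so two different groups at that aromatic carbon gave similar numbers.

Dimethylcarbamoyl is untested here, and a partial return toward compound 1 at 26.7 uM is expected. A further reading at the limit remains possible for compound 4. The expected step is an at least 2.2-fold lower number from compound 3 to compound 4 (0.34 log units; beyond the scatter), towards a lower number. The estimate for compound 4 is 45 uM, with an expected range of 15 uM to 100 uM.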

Compound 4, half-maximal toxic concentration: 80.1 uM
Estimate against measurement, compound 4: 1.8-fold (0.25 log units) below; low and high end bracket the measured number.
By their numbers in this assay, from the lowest: compounds 2 and 1 (each within the scatter of the next); then compound 4. At a limit, above all of these: compound 3.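

In this assay, the dimethylcarbamoyl group on this aromatic carbon keeps the number clearly apart from both the cyano compound and the group in compound 2, with a 3.0-fold higher number from compound 1 to compound 4 (0.48 log units; beyond the scatter) and a 3.5-fold higher number from compound 2 to compound 4 (0.54 log units; beyond the scatter); the higher number therefore does not require the amino group and its hydrogen-bond donor, since compound 4 has no donor in that group. Compound 3 gives > 100 uM, which is a limit and not a number. The effect of dimethylamino in place of amino on the carbonyl carbon is read only as a floor, an at least 1.2-fold lower number from compound 3 to compound 4 (0.09 log units; that floor lies within the scatter), so no real drop can be claimed, because one end of that step is not a number: the limit of > 100 uM in this assay, at which 1 of the 4 values shown sits.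

Open, as far as these compounds go, is whether a methylamino group, a longer chain such as diethylamino, or a carboxylic acid at this aromatic carbon would stay with compound 3 and compound 4 or fall towards compound 1 and compound 2. Also open, from the compounds shown here alone, is whether the same order holds on any cell line other than the one in this assay.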